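Methoxy in Place of Fluoro on the Outer Ring

The compounds below may be only part of what the source reports. "The series", "measured", "known", "first", "only" and "open" are said of these compounds alone.

Of the compounds shown here, three have been measured in an assay on isolated protein for inhibition of ATP-citrate synthase (Homo sapiens); a higher number here means a weaker inhibitor, a lower number a stronger inhibitor. Compound 1 `O=C(O)C[C@](O)(C(=O)O)[C@@H](O)CCCCCCCc1ccc(Cl)cc1Cl` gives 5700 nM in this assay. Compound 2 `O=C(O)C[C@](O)(C(=O)O)[C@@H](O)CCCCCCCCc1ccc(Cl)cc1Cl` gives 18000 nM. Among the measured compounds shown here, the only measured step between close neighbours is a 3.2-fold higher number from compound 1 to compound 2 (0.50 log units; beyond the scatter), and it concerns the saturated chain alone. Compound 3 `O=C(O)C[C@@](O)(C[C@H](O)CCCCCCc1ccc(Cl)cc1-c1ccc(F)cc1)C(=O)O` gives 2700 nM, the lowest of the three numbers, standing beyond the scatter from compound 1 and further still from compound 2.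

Compound 4 `COc1ccc(-c2cc(Cl)ccc2CCCCCC[C@@H](O)C[C@](O)(CC(=O)O)C(=O)O)cc1` is compound 3 with a single change: methoxy in place of fluoro on an aromatic carbon. For the measured compounds named here, no measured step bears on this change. Going by the values given here, the step from compound 1 to compound 2 alters the chain and leaves the outer ring untouched, so it offers no guide to what a methoxy does where a fluoro stood, and no other pair in the set touches that position. With nothing pointing either way, the expected step is one that stays within the scatter, no change at the digits printed from compound 3 to compound 4 (within the scatter). Compound 4 is therefore estimated at 2700 nM in this assay, with a range from 900 nM to 8000 nM to reflect how little the measured data say about this particular swap.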

Compound 4, inhibition constant: 5100 nM
Compound 4: the middle estimate sits 1.9-fold (0.28 log units) below what was measured; measured number inside the range.
By their numbers in this assay, from the lowest: compounds 3, 4 and 1 (each within the scatter of the next, the first and the last beyond it); then compound 2.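

Among the compounds shown here, this is the first measured change on the outer ring. In this assay, going from 4-fluorophenyl to 4-methoxyphenyl puts two heavy atoms where one stood and adds a hydrogen-bond acceptor, and the result is a 1.9-fold higher number from compound 3 to compound 4 (0.28 log units; within the scatter). For this one pair, then, a change on an aromatic carbon para to a large group, from a single fluorine atom to the bigger methoxy, leaves a difference too small to tell apart from the ordinary spread of repeated measurements, so the position shows no clear preference between these two groups. No supporting data are available to say what lies behind this result, or what either group does at this position.

On these data alone, a single pair cannot show how this position responds more generally, so it remains open whether an amine, a carboxylic acid or a nitrile in the same place would also stay within the scatter of compound 3. As far as these compounds go, it is also open whether methoxy in place of fluoro would give a similar result on a longer chain, where the saturated chain length may matter.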